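The compounds below may be only part of what the source reports. "The series", "measured", "known", "first", "only" and "open" are said of these compounds alone.

Compound 1 `O=S(=O)(Nc1ccc2oc(-c3ccccc3)nc2c1)c1ccccc1O`: 85000 nM
Compound 2 `COc1cccc(S(=O)(=O)Nc2ccc3oc(-c4ccccc4)nc3c2)c1`: > 100000 nM
Compound 3 `CS(=O)(=O)Nc1ccc2oc(-c3ccccc3)nc2c1`: > 100000 nM

All three share one core and differ only in the group attached to the sulfonyl sulfur. In an assay on cells for inhibition of HSP60/HSP10 (Homo sapiens), with a stated time of 60 min (a lower number here means a stronger inhibitor, a higher number a weaker inhibitor), compound 1 gives 85000 nM, a weak result. For compound 2 this assay reports only a limit, > 100000 nM, not a number. For compound 3 likewise only a limit is reported, > 100000 nM. As far as these compounds go, compound 3 therefore stands at the edge of what this assay can resolve, so its true number is unknown. The step of an at least 1.1-fold higher number from compound 1 to compound 3 (0.07 log units; that floor lies within the scatter) and the step of an at least 1.1-fold higher number from compound 1 to compound 2 (0.07 log units; that floor lies within the scatter) are both read against that limit, and the step that the two limits leave unreadable from compound 2 to compound 3 is unreadable for the same reason.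

Compound 4 `COc1ccc(S(=O)(=O)Nc2ccc3oc(-c4ccccc4)nc3c2)cc1` is not yet measured. Its change from compound 3 is 4-methoxyphenyl in place of methyl on a sulfonyl sulfur. Going by the values given here, the steps that bear on it, from compound 1 to compound 3 and from compound 2 to compound 3, both involve an aromatic group against methyl and both end at the limit of > 100000 nM in this assay, at which 2 of the 3 values shown sit, so they give no sign that an aromatic group on the sulfonyl sulfur brings a stronger result here. Compound 4 is therefore expected to give about 100000 nM, in the range 40000 nM to 300000 nM, most likely again as a limit. The expected step of a number no higher from compound 3 to compound 4 (the limit leaves the size open) is none beyond the scatter.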

Compound 4, half-maximal inhibitory concentration: > 100000 nM
Compound 4: a limit, no number; the forecaster's own chance of this, stated with the estimate: 70%; the middle value lies on the limit itself.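

With 4-methoxyphenyl on the sulfonyl sulfur, a third group, after 3-methoxyphenyl and methyl, now ends at the same limit of this assay, so a larger aromatic group in place of methyl brings no measurable number here: the limit of > 100000 nM in this assay, at which 3 of the 4 values shown sit. Going by these compounds alone, the one step that can be read is an at least 1.1-fold higher number from compound 1 to compound 4 (0.07 log units; that floor lies within the scatter), so the data show no separation beyond the scatter between 2-hydroxyphenyl and 4-methoxyphenyl, although the true gap may be larger. The steps linking compound 4 to compound 2 and to compound 3 cannot be read, as both ends of each are limits, and the shift of the methoxy group from the 3-methoxyphenyl to the 4-methoxyphenyl arrangement therefore has no readable effect.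

As far as these compounds go, how far apart compound 2, compound 3 and compound 4 truly lie remains open, as all three are known only by the same limit. Also open, from the compounds shown here alone, is whether an amine or a carboxylic acid in place of the hydroxy group of compound 1 would give a number clearly lower than that of compound 1.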